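Ethylcarbamoyl in place of methylcarbamoyl on the bromofluorophenyl analogue

The source may report more compounds than this note shows. Statements on the series, on what has been measured and on what is new or still open speak of the compounds shown alone.

Measured compounds in a functional assay on NCI-H460 cells (Homo sapiens) for antiproliferative activity, read by MTT assay, with a stated time of 72 h; on this read-out lower numbers stand for stronger inhibition and higher numbers for weaker inhibition:
- compound 1 `CNC(=O)c1cc(Oc2ccc(NC(=O)c3cc4cccnc4n(-c4ccc(Br)cc4F)c3=O)cc2)ccn1`: for compound 1 the result is "not determined" (no result reported).
- compound 2 `CNC(=O)c1cc(Oc2ccc(NC(=O)c3cc4cccnc4n(-c4ccc(C(F)(F)F)cc4Cl)c3=O)cc2)ccn1`: compound 2 gives 2110 nM.

Among the compounds with values here, compound 1 has no number in this assay; the only figure is the one from compound 2, which carries a different aryl group on the shared core, so nothing places compound 1 relative to it. Within the data shown here, no step between measured compounds exists.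

Compound 3 `CCNC(=O)c1cc(Oc2ccc(NC(=O)c3cc4cccnc4n(-c4ccc(Br)cc4F)c3=O)cc2)ccn1` differs from compound 1 by methyl in place of hydrogen on a saturated chain carbon bound to an amide-type nitrogen. Since compound 1 itself is unmeasured, no step can be expected in this assay between the two; the change is small and, going by the one figure available, no shift beyond the scatter is anticipated.

For compound 3 the estimated value in this assay is 2000 nM, with an expected range from 600 nM to 7000 nM, anchored loosely on compound 2 giving 2110 nM.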

Compound 3, half-maximal inhibitory concentration: 1790 nM
For compound 3 the middle estimate is 1.1-fold (0.05 log units) above the measured one; low and high end bracket the measured number.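

No step can be read between compound 1 and compound 3 in this assay: compound 1 reads "not determined" (no result reported), and compound 3 reads 1790 nM. On these data alone, what methyl to ethyl does to the read-out on this aryl group stays open. No supporting evidence bears on this result.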